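Trifluoromethyl in place of methoxy on compound 2

The source may report more compounds than this note shows. Statements on the series, on what has been measured and on what is new or still open speak of the compounds shown alone.

In a functional assay on NCI-H661 cells (Homo sapiens) for antiproliferative activity, read by MTT assay, with a stated time of 72 h (a higher number here means a weaker inhibitor, a lower number a stronger inhibitor), compound 1 (`O=C(CCCCCCc1nc(-c2ccc(C(F)(F)F)cc2)no1)NO`) gives 15300 nM and compound 2 (`COc1ccc(-c2noc(CCCCCCC(=O)C(F)(F)F)n2)cc1`) gives 5050 nM as the lower of the two numbers. The gap between them lies beyond the usual scatter, so compound 2 is the stronger inhibitor of this pair, though two measured compounds say little about a series. The unmeasured compound 3 (`O=C(CCCCCCc1nc(-c2ccc(C(F)(F)F)cc2)no1)C(F)(F)F`) is compound 2 with trifluoromethyl in place of methoxy on an aromatic carbon, para to a large group (trifluoromethyl in place of methoxy on an aromatic carbon). Going by the values given here, no measured pair isolates this exchange, so its size cannot be read from the data. The expectation therefore starts from compound 2 at 5050 nM and allows for only a small shift. A step within the scatter is expected in this assay, with the number if anything slightly higher (a 1.2-fold higher number from compound 2 to compound 3 (0.07 log units; within the scatter)). The range is kept wide, as nothing measured yet constrains this exchange. The estimated value for compound 3 is 6000 nM (expected range 2000 nM to 18000 nM).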

Compound 3, half-maximal inhibitory concentration: 6390 nM
Estimate against measurement, compound 3: 1.1-fold (0.03 log units) below; the range from low to high includes it.
By their numbers in this assay, from the lowest: compounds 2 and 3 (each within the scatter of the next); then compound 1.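

In this assay, trifluoromethyl in place of methoxy on an aromatic carbon, para to a large group, gives a 1.3-fold higher number from compound 2 to compound 3 (0.10 log units; within the scatter), so this position accepts either group with no difference that the assay can resolve. Going by these compounds alone, the carbonyl carbon is the place that registers: with trifluoromethyl held on the aromatic ring, trifluoromethyl in place of hydroxyamino gives a 2.4-fold lower number from compound 1 to compound 3 (0.38 log units; beyond the scatter), the only single-place step so far beyond the scatter, though a modest one. Nothing at hand bears on the reason for either step.

Within the data shown here, at the aromatic position only two groups can be compared, so it remains open whether an amine, a carboxylic acid or a plain hydrogen there would also stay within the scatter of compound 2 and compound 3. Among these compounds, also open are whether a longer chain would move the number in this assay and whether the step at the carbonyl carbon keeps its size with methoxy on the aromatic ring, as the single pair available carries trifluoromethyl there.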